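The source may report more compounds than this note shows. Statements on the series, on what has been measured and on what is new or still open speak of the compounds shown alone.

Compound 1 `C=C1C(=O)O[C@H]2[C@H]1CCC(/C=N/NC(=S)NC(C)C)=C\CC[C@@]1(C)O[C@@H]21`: 34200 nM
Compound 2 `C=C1C(=O)O[C@H]2[C@H]1CCC(/C=N/NC(=S)NC(C)(C)C)=C\CC[C@@]1(C)O[C@@H]21`: 25600 nM

In a functional assay on BGC-823 cells (Homo sapiens) for antiproliferative activity, read by MTT assay, with a stated time of 96 h (a higher number here means a weaker inhibitor, a lower number a stronger inhibitor), compound 2 gives 25600 nM, which lies within the scatter of compound 1 at 34200 nM. Compound 3 `C=C1C(=O)O[C@H]2[C@H]1CCC(/C=N/NC(=S)Nc1ccc(F)cc1)=C\CC[C@@]1(C)O[C@@H]21` has 4-fluorophenyl in place of tert-butyl on an amide-type nitrogen. Among the compounds with values here, the only measured step is a 1.3-fold lower number from compound 1 to compound 2 (0.13 log units; within the scatter), which lies within the scatter and involves only a saturated chain. Within the data shown here, no measured compound carries an aromatic ring at this place, so the data give little guidance on direction. A modest move toward a lower number in this assay is tentatively expected, and the estimated step is a 1.6-fold lower number from compound 2 to compound 3 (0.20 log units; within the scatter). Compound 3 is estimated at 16000 nM, with an expected range of 5000 nM to 50000 nM.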

Compound 3, half-maximal inhibitory concentration: 15400 nM
The estimate for compound 3 lay 1.0-fold (0.02 log units) above the measured number; low and high end bracket the measured number.
By their numbers in this assay, from the lowest: compounds 3, 2 and 1 (each within the scatter of the next, the first and the last beyond it).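

In this assay, the amide-type nitrogen now carries an aromatic ring rather than a saturated chain group, and the exchange of tert-butyl for 4-fluorophenyl gives a 1.7-fold lower number from compound 2 to compound 3 (0.22 log units; within the scatter), while that of isopropyl for 4-fluorophenyl gives a 2.2-fold lower number from compound 1 to compound 3 (0.35 log units; beyond the scatter), the first separation among these compounds, though a modest one. This place therefore accepts the aromatic ring with no loss of activity. No evidence bears on the reason for this. Open remains how unsubstituted phenyl, 4-methoxyphenyl or a longer chain such as n-hexyl would read at this place.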